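From methylcarbamoyl to carboxy at the assay limit

The source may hold more compounds than are shown below. What is called first, only, known or untested is meant among the compounds shown, and "the series" means these compounds.

In a functional assay on KB cells (Homo sapiens) for inhibition, read by sulforhodamine B assay, with a stated time of 72 h (a higher number here means a weaker inhibitor of growth, a lower number a stronger inhibitor of growth), compound 1 (`CNC(=O)/C=C/c1ccncc1-c1ccc2ccccc2c1`) gives > 10000 nM, which is a limit and not a number. Compound 2 (`CNC(=O)/C=C/c1ccncc1-c1ccc2cc[nH]c2c1`) gives > 10000 nM, also a limit. Compound 3 (`CCOC(=O)/C=C/c1ccncc1-c1ccc2[nH]ccc2c1`) gives > 10000 nM, again a limit. Within the data shown here, compound 1 therefore stands level with the other two, and no measured step is available to size a change. Compound 4 (`O=C(O)/C=C/c1ccncc1-c1ccc2ccccc2c1`) carries hydroxy in place of methylamino on a carbonyl carbon. The expected step that the limit leaves unreadable from compound 1 to compound 4 is none beyond the scatter in this assay. No stronger growth inhibition is expected because of the limit of > 10000 nM in this assay, at which 3 of the 3 values shown sit. Compound 4 is estimated at 12000 nM, with an expected range from 6000 nM to 30000 nM.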

Compound 4, concentration for 50% growth inhibition: > 10000 nM
Compound 4: only a limit was reported; the forecaster's own chance of this, stated with the estimate: 85%; the middle value lies beyond the limit too.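

Among these compounds, compound 1 and compound 4 each give only a limit, so no step between them can be read. The compounds shown leave open whether any change to the shared core gives a measurable growth inhibition value.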